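Carbonyl in place of sulfonyl on the chain amine

This account rests on a few compounds, and the source may have more. Where it says the series, first, only, none or still open, it means among the compounds named here.

Measured in a functional assay on A-375 cells (Homo sapiens) for cytotoxicity, read by MTT assay; a lower number here means a stronger inhibitor, a higher number a weaker inhibitor:
compound 1 `O=S(=O)(NCCCNc1nccc(-c2c(-c3cccc(F)c3)nc3sccn23)n1)c1ccc(C(F)(F)F)cc1` gives 4090 nM
compound 2 `O=S(=O)(NCCCNc1nccc(-c2c(-c3cccc(F)c3)nc3sccn23)n1)c1ccc(Cl)cc1` gives 5900 nM
compound 3 `O=S(=O)(NCCNc1nccc(-c2c(-c3cccc(F)c3)nc3sccn23)n1)c1ccc(C(F)(F)F)cc1` gives 7440 nM

Compound 2 stands second highest of the three numbers; its nearest neighbour is compound 3 and its furthest compound 1, both within the scatter, so no order among the three can be read. The next compound, compound 4 `O=C(NCCCNc1nccc(-c2c(-c3cccc(F)c3)nc3sccn23)n1)c1ccc(F)cc1`, differs from compound 2 in one place: (4-fluorophenyl)carbonyl in place of (4-chlorophenyl)sulfonyl on an amine nitrogen. Among the compounds with values here, the only measured step, a 1.4-fold higher number from compound 1 to compound 2 (0.16 log units; within the scatter), alters the substituent on the aromatic ring and leaves the sulfonyl untouched, so nothing measured bears on a sulfonyl-to-carbonyl exchange. Hence no step beyond the scatter is expected in this assay, and compound 4 is estimated at 6000 nM, range 1500 nM to 20000 nM. The expected step is a 1.0-fold higher number from compound 2 to compound 4 (0.01 log units; within the scatter), with wide uncertainty.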

Compound 4, half-maximal inhibitory concentration: 14900 nM
Compound 4: middle estimate off by 2.5-fold (0.40 log units), on the low side, within the range that was stated.
By their numbers in this assay, from the lowest: compounds 1, 2, 3 and 4 (each within the scatter of the next, the first and the last beyond it).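

In this assay, (4-fluorophenyl)carbonyl in place of (4-chlorophenyl)sulfonyl on the amine nitrogen gives a 2.5-fold higher number from compound 2 to compound 4 (0.40 log units; beyond the scatter); unlike the chloro-for-trifluoromethyl step, this one lies beyond the scatter, so the group on this nitrogen can move the number. The exchange changes the linking group and the ring halogen together, so the step cannot be assigned to either part alone. No available evidence accounts for the step.

Still open, on these data alone, is how (4-fluorophenyl)sulfonyl or (4-chlorophenyl)carbonyl on this nitrogen would read, since either would separate the two parts. As far as these compounds go, a urea at the same place is also open.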